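The source may hold more compounds than are shown below. What is called first, only, known or untested is meant among the compounds shown, and "the series" means these compounds.

Compound 2 `O=C(O)CCc1ccc(OCc2nnc(C(=O)Nc3cccc(F)c3)s2)cc1` gives 1190 nM in a functional assay on CHO cells for agonist activity at Free fatty acid receptor 1 (Homo sapiens), read by calcium flux; on this read-out higher numbers stand for an effect only at larger amounts of compound and lower numbers for an effect already at smaller amounts; compound 1 `Cc1ccccc1NC(=O)c1nnc(COc2ccc(CCC(=O)O)cc2)s1` gives 1520 nM, and the step of a 1.3-fold lower number from compound 1 to compound 2 (0.11 log units; within the scatter) leaves the two inseparable. Compound 3 `COc1cccc(NC(=O)c2nnc(COc3ccc(CCC(=O)O)cc3)s2)c1` differs from compound 2 by methoxy in place of fluoro on an aromatic carbon. Among the measured compounds shown here, the only measured step that bears on this change is the swap of aryl groups on the amide nitrogen, a 1.3-fold lower number from compound 1 to compound 2 (0.11 log units; within the scatter), which showed nothing beyond the scatter. For compound 3 a step of a 1.0-fold higher number from compound 2 to compound 3 (0.00 log units; within the scatter) in this assay is therefore expected, with no change beyond the scatter. Compound 3 is estimated at 1200 nM, between 500 nM and 3000 nM.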

Compound 3, half-maximal effective concentration: 4680 nM
Estimate against measurement, compound 3: 3.9-fold (0.59 log units) below; the measured number lies above the stated range.
By their numbers in this assay, from the lowest: compounds 2 and 1 (each within the scatter of the next); then compound 3.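

At this position the substituent does register in this assay: methoxy in place of fluoro on the aromatic carbon gives a 3.9-fold higher number from compound 2 to compound 3 (0.59 log units; beyond the scatter), whereas the earlier aryl swap stayed within the scatter. The 3-methoxyphenyl group also separates from 2-methylphenyl on the amide nitrogen, with a 3.1-fold higher number from compound 1 to compound 3 (0.49 log units; beyond the scatter). Nothing offered here accounts for this step.

The compounds shown leave open whether a hydroxyl, an ethoxy or an amine on this aromatic carbon would stand with fluoro or with methoxy.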